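Ring contraction on the amide nitrogen of compound 3

A few compounds are considered here, and "the series" means these few. Any claim that something is new, unique, unknown or untested is made for them only; others in the source may bear on it.

Compound 3 `CCN(CC)S(=O)(=O)c1ccc(S(=O)(=O)N2CCC[C@@H](C(=O)NC3CCOCC3)C2)cc1` gives 3770 nM in a functional assay on MIA PaCa-2 cells (Homo sapiens) for inhibition, read by MTT assay, with a stated time of 7 days (on this read-out higher numbers stand for weaker inhibition and lower numbers for stronger inhibition), the highest number among the three measured compounds. Compound 1 `CCN(CC)S(=O)(=O)c1ccc(S(=O)(=O)N2CCC[C@@H](C(=O)N[C@H]3CC[C@H](OC)CC3)C2)cc1` gives 1350 nM and compound 2 `CCN(CC)S(=O)(=O)c1ccc(S(=O)(=O)N2CCC[C@@H](C(=O)N3CCC(OC)CC3)C2)cc1` gives 140 nM; the step of a 2.8-fold higher number from compound 1 to compound 3 (0.45 log units; beyond the scatter) is modest, while a 27-fold higher number from compound 2 to compound 3 (1.43 log units; beyond the scatter) is large, and a 9.6-fold lower number from compound 1 to compound 2 (0.98 log units; beyond the scatter) shows that the switch between a secondary amide and a tertiary amide carries most of the spread seen so far.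

Compound 4 `CCN(CC)S(=O)(=O)c1ccc(S(=O)(=O)N2CCC[C@@H](C(=O)N[C@H]3CCOC3)C2)cc1` keeps the secondary amide and the shared core and differs only by oxolan-3-yl in place of oxan-4-yl on an amide-type nitrogen. For the measured compounds named here, the measured step that bears most directly on this change is the one from compound 1 to compound 3, which swapped one six-membered substituent for another on the same nitrogen and moved the number by a modest amount. Going by the values given here, no measured step changes the ring size on this nitrogen, so the direction of the effect of oxolan-3-yl is not anchored by the series. With compound 3 as the only close reference, the number for compound 4 is expected to stay near it, with a step of a 1.1-fold lower number from compound 3 to compound 4 (0.03 log units; within the scatter) lying inside the scatter. Compound 4 is therefore estimated at 3500 nM, within a range from 1400 nM to 9000 nM.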

Compound 4, half-maximal inhibitory concentration: 1670 nM
Estimate against measurement, compound 4: 2.1-fold (0.32 log units) above; low and high end bracket the measured number.
By their numbers in this assay, from the lowest: compound 2; then compounds 1 and 4 (each within the scatter of the next); then compound 3.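

In this assay, for the compounds shown here, oxolan-3-yl in place of oxan-4-yl on the amide-type nitrogen gives a 2.3-fold lower number from compound 3 to compound 4 (0.35 log units; beyond the scatter) and is the first reading of ring size at this position, showing that the number responds to this change by more than the scatter. Compound 4 also comes level with the 4-methoxycyclohexyl amide, at a 1.2-fold higher number from compound 1 to compound 4 (0.09 log units; within the scatter) and so within the scatter, which means that two differently built substituents on the secondary amide nitrogen give values that cannot be told apart. The ring contraction does not close the distance to the tertiary amide, with a 12-fold higher number from compound 2 to compound 4 (1.08 log units; beyond the scatter) as the remaining step, so all three secondary amides stay on the higher side of compound 2 by steps beyond the scatter, and none of the four compounds goes against this. Still open, as far as these compounds go, are whether the opposite configuration at the defined stereocentre of oxolan-3-yl gives the same number, and whether an oxetan-3-yl group or a pyrrolidin-3-yl group, which carries a ring amine, would extend the step seen with oxolan-3-yl. Nothing available explains why these steps take the sizes they do.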